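The source may report more compounds than this note shows. Statements on the series, on what has been measured and on what is new or still open speak of the compounds shown alone.

Working notes on the series.

The shared core carries a carbonyl-linked substituent that is varied. In a functional assay on the whole organism for inhibition of sodium-dependent dopamine transporter (Mus musculus) (a lower number here means that less compound is needed, a higher number that more compound is needed for the effect), compound 2, `CCOC(=O)Nc1cccc2c1CN(C)CC2c1ccccc1`, gives 2.5 mg/kg. Compound 3, `CCNCCC(=O)Nc1cccc2c1CN(C)CC2c1ccccc1`, gives 190 mg/kg in this assay, and stands highest of the two numbers shown, with a 76-fold higher number from compound 2 to compound 3 (1.88 log units; beyond the scatter). Compound 1, `CCCNC(=O)Nc1cccc2c1CN(C)CC2c1ccccc1`, reaches only the assay limit of > 120 mg/kg in this assay, as recorded in the limit of > 120 mg/kg in this assay, at which 1 of the 3 values shown sits. From there an at least 48-fold lower number from compound 1 to compound 2 (1.68 log units; beyond the scatter), while a step that the limit leaves unreadable from compound 1 to compound 3.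

Compound 4, `CCCCNCCC(=O)Nc1cccc2c1CN(C)CC2c1ccccc1`, is not yet measured. It differs from compound 3 by ethyl in place of hydrogen on a saturated chain carbon, two bonds along the chain from an amine nitrogen. Within the data shown here, none of the measured steps alters a saturated chain carbon in this way: each swaps the whole group on the carbonyl carbon, and the one step that starts from an amine-bearing chain, from compound 1 to compound 3, is unreadable against the limit. The two chain-amine compounds, compound 1 and compound 3, both sit at high numbers or at the limit, so no large move from compound 3 is expected. Compound 4 is therefore expected near 150 mg/kg, with a range from 40 mg/kg to 500 mg/kg. The expected change is a 1.3-fold lower number from compound 3 to compound 4 (0.10 log units; within the scatter).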

Compound 4, dose for half-maximal effect: > 60 mg/kg
Compound 4 ended at the assay's limit; the forecaster's own chance of this, stated with the estimate: 30%; the middle value lies beyond the limit too.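

In this assay compound 4 stands at a limit of the assay and not at a number: the limit of > 60 mg/kg in this assay, at which 1 of the 4 values shown sits.

Among these compounds, the one readable step is an at least 24-fold higher number from compound 2 to compound 4 (1.38 log units; beyond the scatter), so the butylamino chain on this side of the carbonyl carbon stays clearly apart from the ethoxy group of compound 2, as the ethylamino chain of compound 3 already did. The steps from compound 3 to compound 4 and from compound 1 to compound 4 cannot be read, so the change from ethylamino to butylamino, with ethyl in place of hydrogen on a saturated chain carbon, two bonds along the chain from an amine nitrogen, has no size in this series.

Whether the butylamino chain moves the number at all relative to the ethylamino chain remains undecided, and a value for compound 4 inside the range of the assay would be needed to settle it. Also open, from the compounds shown here alone, is how a longer chain such as hexylamino, or a propoxy group in place of the ethoxy group on the carbonyl carbon, would read in this assay.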